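Isoxazole regioisomer swap in a tert-butyl urea series

The compounds below may be only part of what the source reports. "The series", "measured", "known", "first", "only" and "open" are said of these compounds alone.

Measured so far in an in vitro ADME assay on microsomes from liver (Homo sapiens) for metabolic stability, read by LC-MS; on this read-out higher numbers stand for a longer-lived compound and lower numbers for a shorter-lived compound:
- compound 1, `CCCCc1ccc(NC(=O)N2CCCN(C(=O)CCC3CCCC3)CC2)cc1`, gives 0.0833 h
- compound 2, `CC(C)(C)c1ccc(NC(=O)N2CCCN(C(=O)C3CCOCC3)CC2)cc1`, gives 0.183 h
- compound 3, `CC(C)(C)c1cc(NC(=O)N2CCCN(C(=O)C3CCOCC3)CC2)no1`, gives > 2 h

For compound 3 the value in this assay is a limit of the assay rather than a number, namely (the limit of > 2 h in this assay, at which 1 of the 3 values shown sits). Compound 3 therefore stands at the long-lived end of what has been measured, with only a floor known.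

Compound 4, `CC(C)(C)c1cc(NC(=O)N2CCCN(C(=O)C3CCOCC3)CC2)on1`, differs from compound 3 by 3-(tert-butyl)-1,2-oxazol-5-yl in place of 5-(tert-butyl)-1,2-oxazol-3-yl on an amide-type nitrogen. Going by the values given here, no measured pair covers this kind of change, so its effect in this assay is unknown; the expected step of a number no higher from compound 3 to compound 4 (the limit leaves the size open) is none beyond the scatter, with some chance of a shorter half-life. Compound 4 is expected to give about 2 h in this assay, within a range from 0.7 h to 6 h.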

Compound 4, half-life in the Homo sapiens assay: > 2 h
Compound 4: no number, only a limit (the forecaster's own chance of this, stated with the estimate: 45%); the middle value lies on the limit itself.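

Going by these compounds alone, compound 3 and compound 4 both stand only at assay limits in the Homo sapiens assay and in a physicochemical assay for solubility, at pH 7.4 (a lower number here means a less soluble compound, a higher number a more soluble compound), and no step between them can be read. In the physicochemical assay compound 3 gives > 37 ug/mL as a limit of the assay and not a number. In the physicochemical assay compound 4 gives > 37 ug/mL as a limit of the assay and not a number. From the compounds shown here alone, whether 3-(tert-butyl)-1,2-oxazol-5-yl and 5-(tert-butyl)-1,2-oxazol-3-yl differ on either read-out remains open.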